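This account rests on a few compounds, and the source may have more. Where it says the series, first, only, none or still open, it means among the compounds named here.

Measured compounds:
- compound 1, `CCCCCCC#Cc1cccc(S(=O)(=O)Nc2cccc(-c3csc(NC(C)=O)n3)c2)c1`. In a functional assay on A-375 cells (Homo sapiens) for antiproliferative activity, read by trypan blue exclusion, with a stated time of 48 h, tested at 10 uM (on this read-out lower numbers stand for a stronger effect and higher numbers for a weaker effect at the one concentration tested), compound 1 gives < 1%, which is a limit of the assay and not a number.
- compound 2, `CC(=O)Nc1nc(-c2cccc(NS(=O)(=O)c3cccc(C#CCO)c3)c2)cs1`. In this assay compound 2 gives 45.3%.

Within the data shown here, compound 2 therefore stands on the only real number in this set; the value of compound 1 sits at the limit of < 1% in this assay, at which 1 of the 2 values shown sits. Among the measured compounds shown here, the one measured step, a number at least 44.3 percentage points higher from compound 1 to compound 2 (beyond the scatter), is large. Compound 3, `CC(=O)Nc1nc(-c2cccc(NS(=O)(=O)c3cccc(C#C[Si](C)(C)C)c3)c2)cs1`, carries a group of 4 heavy atoms (3 carbon, 1 silicon; no ring) in place of a group of 2 heavy atoms (1 carbon, 1 oxygen; no ring), on a triple-bonded carbon. That step bears on the measured one only loosely: again a hydroxyl is exchanged for a group without donors or acceptors, here in the opposite sense to the step from compound 1 to compound 2. A step downward, toward a stronger effect, is therefore expected, though its size is uncertain. The estimate for compound 3 in this assay is 15%, within 1% to 45%, meaning an expected step of a number 30.3 percentage points lower from compound 2 to compound 3 (beyond the scatter).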

Compound 3, a percentage reported as activity, at one concentration (the size of the read-out at that concentration, not a potency): 5.8%
Estimate against measurement, compound 3: 9.2 percentage points above, and the stated range covers the measured number.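

Hydroxymethyl on the triple-bonded carbon is now shown to lose ground against two different groups, not just one: exchanging it for the silicon-bearing group gives a number 39.5 percentage points lower from compound 2 to compound 3 (beyond the scatter). So the weaker effect in this assay is not tied to the long chain alone, since a much smaller group with no hydrogen-bond donors or acceptors also gives a strong effect. The step between the two groups without a hydroxyl is a number at least 4.8 percentage points higher from compound 1 to compound 3 (that floor lies within the scatter), and compound 1 stands at a limit of the assay, not a number, so this comparison offers only a floor: the limit of < 1% in this assay, at which 1 of the 3 values shown sits.

As far as these compounds go, what the hydroxyl itself contributes remains open, as does how short a chain can become before the effect fades. A methyl, a methoxymethyl or an aminomethyl on the triple-bonded carbon would help separate these questions.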